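Sulfonyl swap to a methylimidazolyl on the indole nitrogen

The source may report more compounds than this note shows. Statements on the series, on what has been measured and on what is new or still open speak of the compounds shown alone.

Two compounds of this series share one core and differ only in the group on the sulfonyl sulfur. Compound 1 `COc1cc(C)c(Cl)cc1S(=O)(=O)n1c(-c2ccccc2)c(/C=N/N2CCN(C)CC2)c2ccccc21` carries 5-chloro-2-methoxy-4-methylphenyl there, and in a functional assay on HEK293 cells for antagonist activity at 5-hydroxytryptamine receptor 6 (Homo sapiens), read by cAMP accumulation, with stated times of 10 min and 1 h (a higher number here means a weaker inhibitor, a lower number a stronger inhibitor), compound 1 gives 7400 nM. Compound 2 `CN1CCN(/N=C/c2c(-c3ccccc3)n(S(=O)(=O)c3cccc4ccccc34)c3ccccc23)CC1` carries naphthalen-1-yl instead, and in this assay compound 2 gives 6600 nM. The step of a 1.1-fold lower number from compound 1 to compound 2 (0.05 log units; within the scatter) shows that the two numbers cannot be told apart, so compound 2 stands level with compound 1 rather than ahead of it.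

Compound 3 `CN1CCN(/N=C/c2c(-c3ccccc3)n(S(=O)(=O)c3nccn3C)c3ccccc23)CC1` is not yet measured. It differs from compound 2 by 1-methyl-1H-imidazol-2-yl in place of naphthalen-1-yl on a sulfonyl sulfur. Among the compounds with values here, the one step on record at this position, a 1.1-fold lower number from compound 1 to compound 2 (0.05 log units; within the scatter), exchanges one carbon-only aromatic group for another and leaves the number unchanged; no measured step replaces such a group with a small heteroaromatic ring. The record therefore gives no ground for expecting a change beyond the scatter, but also no ground for ruling one out, so the expected range is kept wide. Compound 3 is estimated at 8000 nM, within 2000 nM to 40000 nM, which corresponds to an expected step of a 1.2-fold higher number from compound 2 to compound 3 (0.08 log units; within the scatter).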

Compound 3, half-maximal inhibitory concentration: 3600 nM
For compound 3 the middle estimate is 2.2-fold (0.35 log units) above the measured one, and the stated range covers the measured number.
By their numbers in this assay, from the lowest: compounds 3, 2 and 1 (each within the scatter of the next, the first and the last beyond it).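

Compound 3 shows that a five-membered aromatic ring with 2 hetero atoms, 1-methyl-1H-imidazol-2-yl, can take the place of naphthalen-1-yl on the sulfonyl sulfur with no change that can be told from the scatter in this assay (a 1.8-fold lower number from compound 2 to compound 3 (0.26 log units; within the scatter)). Against 5-chloro-2-methoxy-4-methylphenyl, the same group gives the first step at this position that lies beyond the scatter, though only a modest one (a 2.1-fold lower number from compound 1 to compound 3 (0.31 log units; beyond the scatter)), so the number here is not wholly indifferent to the group on the sulfur. No supporting evidence bears on why this group behaves as it does.

The three compounds carry only aromatic rings on the sulfonyl sulfur, so they leave open how a pyridin-3-yl ring, an imidazole without the methyl group, or a non-aromatic group such as cyclohexyl or a dimethylamino group would read in this assay. They also leave open whether the small step seen with 1-methyl-1H-imidazol-2-yl would hold if the phenyl group or the methylpiperazine of the shared core were replaced, for instance by a pyridine ring or a morpholine.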